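Replacing 4-methylphenyl in compound 1 with an indolyl group

A few compounds are considered here, and "the series" means these few. Any claim that something is new, unique, unknown or untested is made for them only; others in the source may bear on it.

Values so far in a functional assay on A549 cells (Homo sapiens) for inhibition, read by CCK-8 assay, with a stated time of 48 h; on this read-out higher numbers stand for weaker inhibition and lower numbers for stronger inhibition
compound 1 `COc1cc(-c2ccnc3cc(-c4ccc(C)cc4)nn23)cc(OC)c1OC` gives 3 nM
compound 2 `Cn1ccc2cc(-c3cc4nccc(-c5ccc(F)cc5)n4n3)ccc21` gives 3520 nM

Compound 1 holds the lower of the two numbers in this assay and therefore the stronger inhibition, with compound 2 (3520 nM) lying far beyond the scatter from it. Compound 3 `COc1cc(-c2ccnc3cc(-c4ccc5c(ccn5C)c4)nn23)cc(OC)c1OC` keeps the core of compound 1 and changes one group (1-methyl-1H-indol-5-yl in place of 4-methylphenyl on an aromatic carbon), with 1-methyl-1H-indol-5-yl in place of 4-methylphenyl on an aromatic carbon. Compound 2 (3520 nM) also carries 1-methyl-1H-indol-5-yl but differs from compound 1 elsewhere too, so it gives no clean measure of this change and the expectation below is only loosely grounded. The expected change in this assay is a 4.0-fold higher number from compound 1 to compound 3 (0.60 log units; beyond the scatter) toward weaker inhibition, a modest step. For compound 3 the estimated value is 12 nM (expected range 2 nM to 100 nM).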

Compound 3, half-maximal inhibitory concentration: 15 nM
For compound 3 the middle estimate is 1.3-fold (0.10 log units) below the measured one; the range from low to high includes it.
By their numbers in this assay, from the lowest: compound 1; then compound 3; then compound 2.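

In this assay, going by these compounds alone, the change from 4-methylphenyl to 1-methyl-1H-indol-5-yl on the shared core gives a 5.0-fold higher number from compound 1 to compound 3 (0.70 log units; beyond the scatter), the first reading at this position with everything else held constant. The step is modest yet beyond the scatter: this position accepts the larger two-ring group with some loss of inhibition, and compound 3 still gives 15 nM. No measurement shown here accounts for the step.

Compound 2 also carries 1-methyl-1H-indol-5-yl but differs from compound 1 elsewhere too, so the contribution of that other place remains unresolved. As far as these compounds go, it also remains open whether the ring nitrogen or the added ring matters more, which a comparison with 2-naphthyl, or with the indol-5-yl group bearing a free ring hydrogen in place of the methyl, could help separate.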